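The source may hold more compounds than are shown below. What is called first, only, known or untested is meant among the compounds shown, and "the series" means these compounds.

Of the compounds shown here, three of one series have so far been measured in a functional assay on T47D cells (Homo sapiens) for cytotoxicity, read by CCK-8 assay and cell counting, with a stated time of 2 days; a higher number here means a weaker inhibitor, a lower number a stronger inhibitor. Compound 1 `Oc1cccc(-c2cc(-c3ccsc3)nc(-c3cccc(Cl)c3)c2)c1` gives 3540 nM, compound 2 `Oc1ccc(-c2cc(-c3ccsc3)nc(-c3ccccc3Cl)c2)cc1` gives 6110 nM and compound 3 `Oc1ccc(-c2cc(-c3ccsc3)nc(-c3cccc(Cl)c3)c2)cc1` gives 7390 nM. Compound 2 gives the second highest of these three numbers, though both other numbers lie within the scatter of it. Compound 4 `Oc1cccc(-c2cc(-c3ccsc3)nc(-c3ccccc3Cl)c2)c1` differs from compound 2 by 3-hydroxyphenyl in place of 4-hydroxyphenyl on an aromatic carbon. Among the compounds with values here, two measured steps bear on this. a 2.1-fold higher number from compound 1 to compound 3 (0.32 log units; beyond the scatter) is the same change run in the opposite direction. a 1.2-fold higher number from compound 2 to compound 3 (0.08 log units; within the scatter) shows that the chlorophenyl change alone stays within the scatter, so compound 4 may be regarded as a close analogue of compound 1. A modest lowering of the number in this assay is therefore expected, a 2.0-fold lower number from compound 2 to compound 4 (0.31 log units; beyond the scatter). For compound 4 the estimate is 3000 nM, with a range from 1500 nM to 6500 nM.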

Compound 4, half-maximal inhibitory concentration: 2440 nM
For compound 4 the middle estimate is 1.2-fold (0.09 log units) above the measured one; low and high end bracket the measured number.
By their numbers in this assay, from the lowest: compounds 4, 1, 2 and 3 (each within the scatter of the next, the first and the last beyond it).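

In this assay, moving to 3-hydroxyphenyl on the 2-chlorophenyl core gives a 2.5-fold lower number from compound 2 to compound 4 (0.40 log units; beyond the scatter), so the preference for 3-hydroxyphenyl over 4-hydroxyphenyl now holds on two cores: the same change on two cores in this assay, a 2.1-fold higher number (0.32 log units; beyond the scatter) from compound 1 to compound 3 and a 2.5-fold higher number (0.40 log units; beyond the scatter) from compound 4 to compound 2, 1.2-fold (0.08 log units) apart, within the scatter of two such steps. With 3-hydroxyphenyl in place, the chlorophenyl swap gives a 1.5-fold lower number from compound 1 to compound 4 (0.16 log units; within the scatter), so the 2-chlorophenyl and 3-chlorophenyl groups stay indistinguishable here as well: the same change on two cores in this assay, a 1.2-fold higher number (0.08 log units; within the scatter) from compound 2 to compound 3 and a 1.5-fold higher number (0.16 log units; within the scatter) from compound 4 to compound 1, 1.2-fold (0.08 log units) apart, within the scatter of two such steps.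

From the compounds shown here alone, it remains open whether the hydroxyl is needed at all at this position opposite the ring nitrogen. An unsubstituted phenyl, a methoxyphenyl or an aminophenyl there would address that.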